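Chlorothiophene for chlorophenyl at the benzylic ether position

The source may report more compounds than this note shows. Statements on the series, on what has been measured and on what is new or still open speak of the compounds shown alone.

Measured so far:
compound 1 `Cn1c(C2CC2)nc2ccc(-n3ccc(OCc4ccc(Cl)cc4)cc3=O)cc21`: 21 nM
compound 2 `CCn1c(C2CC2)nc2ccc(-n3ccc(OCc4ccc(Cl)cc4)cc3=O)cc21`: 34 nM

In an assay on CHO cells for displacement of a labelled ligand from melanin-concentrating hormone receptor 1 (Rattus norvegicus), read by scintillation counting, with a stated time of 1 h (a lower number here means a stronger inhibitor, a higher number a weaker inhibitor), compound 1 gives 21 nM, the lowest of the two numbers, with compound 2 nearest at 34 nM; the step of a 1.6-fold higher number from compound 1 to compound 2 (0.21 log units; within the scatter) is within the scatter. Compound 3 `Cn1c(C2CC2)nc2ccc(-n3ccc(OCc4csc(Cl)c4)cc3=O)cc21` differs from compound 1 by 5-chlorothiophen-3-yl in place of 4-chlorophenyl on a saturated chain carbon bound to an oxygen on an aromatic ring. Among the measured compounds shown here, no measured step touches this part of the molecule; the only step known concerns the alkyl on the aromatic nitrogen. With nothing to anchor it, a step beyond the scatter is not expected, and compound 3 is estimated at 30 nM (range 10 nM to 90 nM), a step of a 1.4-fold higher number from compound 1 to compound 3 (0.15 log units; within the scatter).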

Compound 3, half-maximal inhibitory concentration: 9.3 nM
Compound 3: middle estimate off by 3.2-fold (0.51 log units), on the high side; measured number outside the range, below it.
By their numbers in this assay, from the lowest: compound 3; then compounds 1 and 2 (each within the scatter of the next).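

On a saturated chain carbon bound to an oxygen on an aromatic ring, 5-chlorothiophen-3-yl in place of 4-chlorophenyl gives, in this assay, a 2.3-fold lower number from compound 1 to compound 3 (0.35 log units; beyond the scatter), a modest gain beyond the scatter. Among the compounds shown here, this position therefore responds to a change of ring, whereas the only earlier step, at the alkyl on the aromatic nitrogen, stayed within the scatter. No supporting data bear on the reason for this step.

The result does not separate the contribution of the sulfur from that of the ring size. From the compounds shown here alone, whether the chlorine is needed also stays open, and an unsubstituted thiophene, 5-methylthiophen-3-yl or a pyridine ring here would address both questions.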